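Swapping acetyl for benzyl on compound 2

This account rests on a few compounds, and the source may have more. Where it says the series, first, only, none or still open, it means among the compounds named here.

Measured in a functional assay on MDA-MB-231 cells (Homo sapiens) for antiproliferative activity, read by MTT assay, with a stated time of 72 h; on this read-out higher numbers stand for weaker inhibition and lower numbers for stronger inhibition:
- compound 1 `CC1=CC[C@H]2[C@H](CC[C@]2(C)O)C(C)(C)[C@@H]1CC[C@H]1[C@]2(C)CC[C@H](OC(=O)c3ccccc3)C(C)(C)O[C@H]2CC[C@@]1(C)O` gives 16100 nM
- compound 2 `CC(=O)O[C@H]1CC[C@]2(C)[C@H](CC[C@@](C)(O)[C@H]2CC[C@@H]2C(C)=CC[C@@H]3C(C)=CC[C@@H]3C2(C)C)OC1(C)C` gives 39200 nM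
- compound 3 `CC1=CC[C@H]2[C@H](CC[C@]2(C)O)C(C)(C)[C@@H]1CC[C@H]1[C@]2(C)CC[C@H](OCc3ccccc3)C(C)(C)O[C@H]2CC[C@@]1(C)O` gives 29100 nM

The value of compound 2 lies within the scatter of compound 3 and beyond the scatter above compound 1. Compound 4 `CC1=CC[C@H]2[C@@H]1CC=C(C)[C@@H](CC[C@H]1[C@]3(C)CC[C@H](OCc4ccccc4)C(C)(C)O[C@H]3CC[C@@]1(C)O)C2(C)C` follows from compound 2 by one change, (benzyl in place of acetyl on an oxygen on a saturated carbon), benzyl in place of acetyl on an oxygen on a saturated carbon. Going by the values given here, no measured step removes acetyl. The nearest is a 1.8-fold higher number from compound 1 to compound 3 (0.26 log units; within the scatter), where benzyl replaces benzoyl. Compound 3, which carries benzyl, also stays within the scatter of compound 2. No step beyond the scatter is therefore expected in this assay. The expected step is a 1.2-fold lower number from compound 2 to compound 4 (0.09 log units; within the scatter) as estimated here. For compound 4 the estimate is 32000 nM, with an expected range from 14000 nM to 70000 nM as its ends.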

Compound 4, half-maximal inhibitory concentration: 35700 nM
Compound 4: middle estimate off by 1.1-fold (0.05 log units), on the low side; low and high end bracket the measured number.
By their numbers in this assay, from the lowest: compounds 1, 3, 4 and 2 (each within the scatter of the next, the first and the last beyond it).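

In this assay, the change from acetoxy to benzyloxy gives a 1.1-fold lower number from compound 2 to compound 4 (0.04 log units; within the scatter), so this place on the core tolerates a swap from a group without a ring to one with a six-membered aromatic ring. Going by these compounds alone, the only earlier step here, a 1.8-fold higher number from compound 1 to compound 3 (0.26 log units; within the scatter), started from benzoyl, which already carries such a ring, and it also stayed within the scatter. No evidence is available to explain this outcome. Going by these compounds, whether an amine or a carboxylic acid in this place would shift the number remains open, as does the effect of benzoyl on the core of compound 2.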